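A Hydroxyphenyl Ketone on the Shared Core

A few compounds are considered here, and "the series" means these few. Any claim that something is new, unique, unknown or untested is made for them only; others in the source may bear on it.

The measured compounds:
compound 1 `COc1cc(-c2nnc3n2NC(c2ccco2)C(C(=O)c2ccco2)S3)cc(OC)c1OC` gives > 100000 nM
compound 2 `COc1cc(-c2nnc3n2NC(c2ccco2)C(C(=O)c2ccccc2F)S3)cc(OC)c1OC` gives > 100000 nM
compound 3 `COc1cc(-c2nnc3n2NC(c2ccco2)C(C(=O)c2ccccc2)S3)cc(OC)c1OC` gives 90900 nM

In a functional assay on HepG2 cells (Homo sapiens) for cytotoxicity, read by MTT assay, with a stated time of 48 h (a lower number here means a stronger inhibitor, a higher number a weaker inhibitor), compound 1 gives only a limit of the assay, > 100000 nM. Compound 2 likewise gives only a limit, > 100000 nM. Among the measured compounds shown here, compound 3 is the one compound with a number, 90900 nM. Compound 1 therefore stands at the limit (the limit of > 100000 nM in this assay, at which 2 of the 3 values shown sit), where two of the three values sit.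

The step to compound 4 `COc1cc(-c2nnc3n2NC(c2ccco2)C(C(=O)c2ccc(O)cc2)S3)cc(OC)c1OC` is 4-hydroxyphenyl in place of furan-2-yl on a carbonyl carbon. Three steps at the same carbonyl carbon or on its aromatic ring have been measured: a step that the two limits leave unreadable from compound 1 to compound 2, an at least 1.1-fold lower number from compound 1 to compound 3 (0.04 log units; that floor lies within the scatter) and an at least 1.1-fold lower number from compound 2 to compound 3 (0.04 log units; that floor lies within the scatter). None of them reaches beyond the scatter, and every replacement of the furan-2-yl ring on that carbonyl carbon has left the value at or close to the limit. For compound 4 no step beyond the scatter is therefore expected, a number no higher from compound 1 to compound 4 (the limit leaves the size open), and a limit is the likeliest outcome. Compound 4 is estimated at 100000 nM, with a range from 50000 nM to 300000 nM.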

Compound 4, half-maximal inhibitory concentration: > 100000 nM
Compound 4 ended at the assay's limit (the forecaster's own chance of this, stated with the estimate: 70%); the middle value sits exactly at the limit.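

Placing a hydroxy group on the phenyl ring of compound 3 gives an at least 1.1-fold higher number from compound 3 to compound 4 (0.04 log units; that floor lies within the scatter) in this assay, so the one ketone shown with a hydrogen-bond donor on its ring brings no lowering of the number. Compound 4 gives only a limit of the assay, and this position now holds one more aromatic replacement that leaves the value there: the limit of > 100000 nM in this assay, at which 3 of the 4 values shown sit. The steps from compound 1 and from compound 2 to compound 4 cannot be read, since both ends of each are limits.

The compounds shown leave open whether any group on this carbonyl carbon can move the value clearly beyond the scatter. Whether an amine or a carboxylic acid on the phenyl ring, or a longer chain in its place, would do so remains an open question.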